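Swapping the amide aryl group on a short-chain analogue

The compounds below may be only part of what the source reports. "The series", "measured", "known", "first", "only" and "open" are said of these compounds alone.

Compound 1 `Cn1c(Cc2nn(C)c(=O)c3ccccc23)nnc1SCCCCCCCC(=O)Nc1ccc(Cl)cc1`: 800 nM
Compound 2 `Cc1ccc(NC(=O)CCCCCCCSc2nnc(Cc3nn(C)c(=O)c4ccccc34)n2C)c(Cl)c1`: 2300 nM
Compound 3 `CCCOc1ccc(NC(=O)CSc2nnc(Cc3nn(C)c(=O)c4ccccc34)n2C)cc1`: > 30000 nM

In an assay on isolated protein (Mus musculus) for inhibition of IL15-IL15 receptor (Homo sapiens), read by resazurin assay, with stated times of 30 min and 2.5 days (a lower number here means a stronger inhibitor, a higher number a weaker inhibitor), compound 3 reaches only a limit, > 30000 nM, the same limit as in the limit of > 30000 nM in this assay, at which 1 of the 3 values shown sits. Compound 4 `Cn1c(Cc2nn(C)c(=O)c3ccccc23)nnc1SCC(=O)Nc1ccc(Cl)cc1Cl` differs from compound 3 by 2,4-dichlorophenyl in place of 4-propoxyphenyl on an amide-type nitrogen. Among the measured compounds shown here, the one measured step that also swaps the aryl group on an amide-type nitrogen is a 2.9-fold higher number from compound 1 to compound 2 (0.46 log units; beyond the scatter), which shows that such a swap shifts this assay by a modest amount. Starting from a limit, no direction can be fixed, and a modest shift would likely leave compound 4 near the same limit. Compound 4 is therefore expected at 25000 nM, between 5000 nM and 60000 nM, a step of an at least 1.2-fold lower number from compound 3 to compound 4 (0.07 log units; that floor lies within the scatter).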

Compound 4, half-maximal inhibitory concentration: 17300 nM
Beside the measured number, compound 4's estimate is 1.4-fold (0.16 log units) above it, within the range that was stated.
By their numbers in this assay, from the lowest: compound 1; then compound 2; then compound 4. At a limit, above all of these: compound 3.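

In this assay, 2,4-dichlorophenyl on the amide-type nitrogen gives compound 4 a measured number, which 4-propoxyphenyl did not give. Compound 3 stands at a limit, > 30000 nM. On these data alone, the change is an at least 1.7-fold lower number from compound 3 to compound 4 (0.23 log units; that floor lies within the scatter), so this swap brings a readable value, while the true size of the step stays unknown.

Still open, as far as these compounds go, is how 2,4-dichlorophenyl would behave on a longer chain. Also open, from the compounds shown here alone, is whether an amine or a carboxylic acid on the aryl ring would move the number further.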